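Replacing an acrylamide with an epoxide on a bis-trifluoromethyl ring

A few compounds are considered here, and "the series" means these few. Any claim that something is new, unique, unknown or untested is made for them only; others in the source may bear on it.

Compound 1, `C=CC(=O)Nc1cc(C(F)(F)F)cc(C(F)(F)F)c1`: 6.1 h
Compound 2, `C#Cc1cc(C(F)(F)F)cc(C(F)(F)F)c1`: 5.9 h
Compound 3, `N#Cc1cc(C(F)(F)F)cc(C(F)(F)F)c1`: 50 h

These three compounds share one core and differ only in the group attached to it. In an ADME assay for pharmacokinetics, read by LC-MS, in phosphate buffer, with a stated time of 72 h, at pH 7.4, tested at 250 uM (a higher number here means that the compound lasts longer, a lower number that the compound disappears faster), compound 1 gives 6.1 h, the second highest of the three numbers; its nearest neighbour is compound 2 (a 1.0-fold lower number from compound 1 to compound 2 (0.01 log units; within the scatter)), its furthest is compound 3 (an 8.2-fold higher number from compound 1 to compound 3 (0.91 log units; beyond the scatter)).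

Compound 4, `FC(F)(F)c1cc(C2CO2)cc(C(F)(F)F)c1`, has not yet been measured. It differs from compound 1 in one place: oxiran-2-yl in place of (vinylcarbonyl)amino on an aromatic carbon.

For the measured compounds named here, none of the measured steps swaps in an oxiran-2-yl group, so no step bears on this change directly. The available comparisons show that exchanging the group at this position can leave the number essentially unchanged, as in a 1.0-fold lower number from compound 1 to compound 2 (0.01 log units; within the scatter), or raise it modestly, as in an 8.2-fold higher number from compound 1 to compound 3 (0.91 log units; beyond the scatter) and an 8.5-fold higher number from compound 2 to compound 3 (0.93 log units; beyond the scatter). Going by the values given here, with no closer precedent, the expectation for compound 4 in this assay is a number close to that of compound 1, with no step beyond the scatter, and a wide range to either side to reflect the uncertainty.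

The estimated value for compound 4 is 5 h, expected to fall between 1.5 h and 20 h. The step this implies is expected to be a 1.2-fold lower number from compound 1 to compound 4 (0.09 log units; within the scatter).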

Compound 4, half-life: > 50 h
Compound 4: only a limit was reported; the forecaster's own chance of this, stated with the estimate: 5%; middle value at least 10-fold (1.00 log units) from the limit.
By their numbers in this assay, from the lowest: compounds 2 and 1 (each within the scatter of the next); then compound 3.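

In this assay compound 4 gives a limit rather than a number: the limit of > 50 h in this assay, at which 1 of the 4 values shown sits. Even so, the limit is enough to place the change: oxiran-2-yl in place of (vinylcarbonyl)amino gives an at least 8.1-fold higher number from compound 1 to compound 4 (0.91 log units; beyond the scatter), and oxiran-2-yl in place of ethynyl gives an at least 8.4-fold higher number from compound 2 to compound 4 (0.92 log units; beyond the scatter). The earlier compounds shown here showed only the cyano group of compound 3 raising the number beyond the scatter at this position, so the oxiran-2-yl group, a three-membered ring with one hetero atom, is now a second and quite different group that does so. The remaining step is a number no lower from compound 3 to compound 4 (the limit leaves the size open), and its size cannot be read.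

The compounds shown leave open how long compound 4 actually lasts in this assay, and so whether it differs from compound 3 at all. They also leave open whether the ring oxygen matters, which a cyclopropyl group, an all-carbon ring, or an open chain such as a hydroxyethyl group at the same place on the shared core could help to settle.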